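This account rests on a few compounds, and the source may have more. Where it says the series, first, only, none or still open, it means among the compounds named here.

Compound 1 `CCCCCCc1cn(-c2ccc(O)c(C(=O)NCCC)c2)nn1` gives 19700 nM in a functional assay on RAW264.7 cells (Mus musculus) for inhibition, read by Griess assay, with a stated time of 20 h; a higher number here means a weaker inhibitor, a lower number a stronger inhibitor.
Compound 2 `CCCNC(=O)c1cc(-n2cc(-c3cccc(Cl)c3)nn2)ccc1O` gives > 20000 nM in this assay; this value is a limit of the assay, not a number.
Compound 3 `CCCCCCc1cn(-c2ccc(C(=O)N3CCCCC3)c(O)c2)nn1` gives > 20000 nM in this assay; this value is also a limit of the assay.

Compounds 1 and 2 share a core and differ by 3-chlorophenyl in place of hexyl on an aromatic carbon. That change gives an at least 1.0-fold higher number from compound 1 to compound 2 (0.00 log units; that floor lies within the scatter), so the replacement did not sharpen inhibition; it may have weakened it, because the limit of > 20000 nM in this assay, at which 2 of the 3 values shown sit, hides how far. Compound 3 carries a different core, and the difference between the two cores is not broken down here.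

Compound 4 `O=C(c1ccc(-n2cc(-c3cccc(Cl)c3)nn2)cc1O)N1CCCCC1` is not yet measured. It relates to compound 3 by 3-chlorophenyl in place of hexyl on an aromatic carbon, the same change that turned compound 1 into compound 2. Since compound 3 already sits at the limit, and the same change from compound 1 to compound 2 brought no gain, compound 4 is expected to stay at or past that limit in this assay, with an expected step that the limit leaves unreadable from compound 3 to compound 4. The estimate for compound 4 is 35000 nM, expected to fall between 15000 nM and 90000 nM.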

Compound 4, half-maximal inhibitory concentration: > 20000 nM
Compound 4: a limit, no number; the forecaster's own chance of this, stated with the estimate: 85%; the middle value is on the limit's open side.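

Compound 3 and compound 4 both give only a limit in this assay, not a number, so the step between them cannot be read: the limit of > 20000 nM in this assay, at which 3 of the 4 values shown sit.

The compounds shown leave open how far 3-chlorophenyl in place of hexyl actually changes inhibition on either core, and whether the compounds sitting at the limit differ from one another at all.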